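Pyrazole amide series: reversed amide with neopentyl chain

The source may report more compounds than this note shows. Statements on the series, on what has been measured and on what is new or still open speak of the compounds shown alone.

Compound 3 `Cc1cc(C(=O)Nc2ccc(F)cc2)nn1Cc1cc(Cl)ccc1OCc1ccccc1` gives 3 in a physicochemical assay for lipophilicity, at pH 7.4 (a higher number here means a more lipophilic compound, a lower number a more polar compound), the highest of the two numbers in hand. Its nearest neighbour is compound 1 `Cc1cc(C(=O)O)nn1Cc1cc(Br)ccc1OCc1ccccc1`, which gives 1.2 in this assay, a gap that is beyond the scatter. Compound 2 `Cc1cc(C(=O)Nc2ccccc2)nn1Cc1cc(Cl)ccc1OCc1ccccc1` returns only a limit in this assay, > 3.7, not a number, (the limit of > 3.7 in this assay, at which 1 of the 3 values shown sits). For the measured compounds named here, the single measured step, a number at least 0.70 log units lower from compound 2 to compound 3 (beyond the scatter), concerns fluoro in place of hydrogen on an aromatic carbon of the carbamoyl phenyl, and is at least modest.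

Compound 4 `Cc1cc(NC(=O)CC(C)(C)C)nn1Cc1cc(Cl)ccc1OCc1ccccc1` is not yet measured. It differs from compound 3 by (neopentylcarbonyl)amino in place of (4-fluorophenyl)carbamoyl on an aromatic carbon. The (4-fluorophenyl)carbamoyl group is gone and a (neopentylcarbonyl)amino group stands on the same aromatic carbon of the five-membered ring, so the amide is turned round and the aromatic ring of the leaving group is replaced by a branched chain with no ring. Going by the values given here, none of the measured steps covers this change; the fluoro step from compound 2 to compound 3 does not bear on it directly. The donor and acceptor count is unchanged.

The step of a number 0.20 log units higher from compound 3 to compound 4 (within the scatter) is expected to stay within the scatter or slightly above it. For compound 4 the value expected in this assay is 3.2, with a range from 2.6 to 3.8.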

Compound 4, distribution coefficient: > 3.7
Compound 4: no number, only a limit (the forecaster's own chance of this, stated with the estimate: 15%); middle value at least 0.50 log units from the limit.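

In this assay, for the compounds shown here, the exchange of (4-fluorophenyl)carbamoyl for (neopentylcarbonyl)amino on this aromatic carbon gives a number at least 0.70 log units higher from compound 3 to compound 4 (beyond the scatter), the first reading of a change at this position rather than on the carbamoyl phenyl. The group that enters has no ring, yet the hydrogen-bond donor and acceptor counts of the two groups are the same, so those counts do not separate compound 3 from compound 4 and an aromatic ring in this substituent is not needed for the read-out to rise this far. From the compounds shown here alone, compound 4 returns a limit and not a number, so the full size of its step stays unknown and the step between compound 2 and compound 4 cannot be read, the top of the range now holding compound 2 as well as compound 4: the limit of > 3.7 in this assay, at which 2 of the 4 values shown sit.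

The turning of the amide and the exchange of the aromatic ring for the branched chain arrive together, so the compounds shown do not divide the step between them. Going by these compounds, whether a shorter chain, or an amine on the chain, would bring the reversed amide back inside the readable range of this assay remains open.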